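Cyclohexyl for Phenyl on the Amide Nitrogen

The source may hold more compounds than are shown below. What is called first, only, known or untested is meant among the compounds shown, and "the series" means these compounds.

In a functional assay on A-375 cells (Homo sapiens) for antiproliferative activity, read by MTT assay, with a stated time of 72 h (a higher number here means a weaker inhibitor, a lower number a stronger inhibitor), compound 1 `O=C1COc2ccc(-c3cccc(NS(=O)(=O)c4ccc(F)cc4)c3)cc2N1c1ccccc1` gives only a limit, > 40000 nM. The two companions measured alongside it fare the same way. Compound 2 `O=C1COc2ccc(-c3cnc4ccccc4c3)cc2N1` returns a limit of > 40000 nM in this assay. Compound 3 `O=C1COc2ccc(-c3cnc(Cl)c(NS(=O)(=O)c4ccc(F)cc4)c3)cc2N1C1CCCCC1` likewise returns a limit of > 40000 nM in this assay. Thus the limit of > 40000 nM in this assay, at which 3 of the 3 values shown sit, describes the whole measured set: compound 1 stands at the limit together with the other two, and nothing in these numbers separates it from them.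

Compound 4 `O=C1COc2ccc(-c3cccc(NS(=O)(=O)c4ccc(F)cc4)c3)cc2N1C1CCCCC1` differs from compound 1 by cyclohexyl in place of phenyl on an amide-type nitrogen in a ring. For the measured compounds named here, no pair of measured compounds isolates this particular change, so its effect cannot be read from a measured step. What the set does offer is compound 3, which carries a cyclohexyl on the same amide-type nitrogen and in this assay sits at the limit > 40000 nM.

Given that every measured compound, with or without cyclohexyl on that nitrogen, stays at the limit, the step that the limit leaves unreadable from compound 1 to compound 4 is expected to be none beyond the scatter. Compound 4 is therefore estimated at 50000 nM in this assay, between 15000 nM and 150000 nM, and is expected most likely to be reported as a limit once more.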

Compound 4, half-maximal inhibitory concentration: 23800 nM
Compound 4: the middle estimate sits 2.1-fold (0.32 log units) above what was measured; the range from low to high includes it.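

Cyclohexyl in place of phenyl on the amide-type nitrogen in a ring gives the first reading in this set that is a number and not a limit, and the step is an at least 1.6-fold lower number from compound 1 to compound 4 (0.22 log units; that floor lies within the scatter). The two groups match in their count of heavy atoms and differ in that one ring is aromatic and the other is not, so this pair ties the step to that single difference in this assay, though the step is only a floor and what is printed does not carry it beyond the scatter. The number for compound 4 also stands alone, as the rest of the set stays at the limit: the limit of > 40000 nM in this assay, at which 3 of the 4 values shown sit.

The compounds shown give no number for compound 1, and the true size of the step remains unknown. They also leave open how this nitrogen would read with cyclopentyl, an open chain such as n-butyl, or a cyclohexyl carrying an amine or a carboxylic acid.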